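The source may report more compounds than this note shows. Statements on the series, on what has been measured and on what is new or still open speak of the compounds shown alone.

Of the compounds shown here, three of a shared core have been measured in a functional assay on MCF7 cells (Homo sapiens) for cytotoxicity, read by MTT assay, with a stated time of 72 h; on this read-out higher numbers stand for weaker inhibition and lower numbers for stronger inhibition. Compound 1 `CNC(=O)c1cc(Oc2ccc(NC(=O)c3nn(-c4ccccc4C(F)(F)F)c(=O)cc3C)cc2F)ccn1` gives 35700 nM in this assay. Compound 2 `Cc1cc(=O)n(-c2ccccc2C(F)(F)F)nc1C(=O)Nc1ccc(Oc2ncnc3ccsc23)cc1` gives 5550 nM, and compound 3 `Cc1cc(=O)n(-c2ccc(Br)cc2F)nc1C(=O)Nc1ccc(Oc2ncnc3ccsc23)cc1` gives 9360 nM. Among these three numbers compound 3 stands second highest: its nearest neighbour is compound 2, whose value lies within the scatter of repeated measurement, while compound 1 sits furthest away, beyond that scatter.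

Among the compounds with values here, the only step among the measured compounds that changes the aryl group on the aromatic nitrogen is the one from compound 2 to compound 3, which gave a 1.7-fold higher number from compound 2 to compound 3 (0.23 log units; within the scatter). Compound 4 `Cc1cc(=O)n(-c2cccc(F)c2)nc1C(=O)Nc1ccc(Oc2ncnc3ccsc23)cc1` is not yet measured in this assay, and it differs from compound 3 at the same place: 3-fluorophenyl in place of 4-bromo-2-fluorophenyl on an aromatic nitrogen. Within the data shown here, since the one comparable swap of the aryl on that nitrogen stayed within the scatter, the same change is expected to leave the number in this assay essentially where it is, with no step beyond the scatter in either direction, which is what the expected step from compound 3 to compound 4, a 1.2-fold lower number from compound 3 to compound 4 (0.10 log units; within the scatter), means. On that basis compound 4 is estimated at 7500 nM in this assay, with a range from 3000 nM to 19000 nM.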

Compound 4, half-maximal inhibitory concentration: 6410 nM
Estimate against measurement, compound 4: 1.2-fold (0.07 log units) above; measured number inside the range.
By their numbers in this assay, from the lowest: compounds 2, 4 and 3 (each within the scatter of the next); then compound 1.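

Within the data shown here, with this swap, three different aryl groups on the aromatic nitrogen of the shared core can be compared in this assay, where before there was only one pair. Taking out the 4-bromo-2-fluorophenyl group for 3-fluorophenyl, which carries no bromine, gave a 1.5-fold lower number from compound 3 to compound 4 (0.16 log units; within the scatter), and replacing 2-(trifluoromethyl)phenyl with the same 3-fluorophenyl gave a 1.2-fold higher number from compound 2 to compound 4 (0.06 log units; within the scatter), so compounds 2, 3 and 4 all lie within the scatter of one another and this position has so far shown no response to the change of substituents on the phenyl ring. No other measurement is available here to account for that flatness.

The compounds shown carry only fluorine, bromine or trifluoromethyl on that phenyl ring, so it remains open whether an amine, a carboxylic acid or a longer chain such as a morpholinoethoxy group there, or an unsubstituted phenyl or a saturated ring in its place, would move the number beyond the scatter. Going by these compounds, it is also open whether the same swaps would read the same way on the core of compound 1, which is represented here by a single aryl group.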